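The source may hold more compounds than are shown below. What is called first, only, known or untested is meant among the compounds shown, and "the series" means these compounds.

Working notes on the isoxazole ether series. Three compounds carry numbers in an assay on isolated protein for agonist activity at Bile acid receptor (Homo sapiens), read by FRET (on this read-out higher numbers stand for larger maximal responses and lower numbers for smaller maximal responses), so far. Compound 1 `Cc1nc(OCc2c(-c3c(Cl)cccc3Cl)noc2C(C)C)ccc1N(C)C(=O)c1ccc(C(=O)O)cc1` gives 95% in this assay. Compound 2 `CC(C)c1onc(-c2c(Cl)cccc2Cl)c1COc1ccc(N(C)C(=O)c2cccc(C(=O)O)c2)c(C(F)(F)F)n1`, which carries the (3-carboxyphenyl)carbonyl on the ring nitrogen and a trifluoromethyl on the shared core, gives 110% in this assay. Compound 3 `Cc1cc(OCc2c(-c3c(Cl)cccc3Cl)noc2C(C)C)ncc1[N+](=O)[O-]`, a nitro-bearing member without the amide arm, gives 101% in this assay. Within the data shown here, compound 2 and compound 3 cannot be told apart within the scatter; compound 1 lies beyond the scatter below compound 2, so compound 2 stands at the upper edge of what the three numbers show, with no measured step between any two of them.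

Compound 4 `CC(C)c1onc(-c2c(Cl)cccc2Cl)c1COc1ccc(N(C)Cc2ccc(OCCO)cc2)c(C(F)(F)F)n1` is the next member, not yet measured. It keeps the core of compound 2 and changes the arm on the ring nitrogen: 4-(2-hydroxyethoxy)benzyl in place of (3-carboxyphenyl)carbonyl on a nitrogen on an aromatic ring. The (3-carboxyphenyl)carbonyl leaves, with its two double bonds outside aromatic rings, and the 4-(2-hydroxyethoxy)benzyl enters, so the nitrogen now neighbours a saturated chain carbon.

Among the measured compounds shown here, no measured pair covers a change of this kind, so the expectation rests on the numbers of compound 2 alone. For the measured compounds named here, because compound 2 gives 110% with the carbonyl arm in place, and no measured compound shows a benzyl arm, a downward step beyond the scatter is expected, of the size a number 35 percentage points lower from compound 2 to compound 4 (beyond the scatter). Compound 4 is therefore estimated at 75% in this assay, within a range from 40% to 110%.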

Compound 4, largest response reached (reported as efficacy), in percent of the reference or control that the assay uses: 87%
Beside the measured number, compound 4's estimate is 12 percentage points below it; the measured number falls inside the stated range.
By their numbers in this assay, from the lowest: compounds 4, 1, 3 and 2 (each within the scatter of the next, the first and the last beyond it).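

Among these compounds, on a nitrogen on an aromatic ring, 4-(2-hydroxyethoxy)benzyl in place of (3-carboxyphenyl)carbonyl gives the first single-place step in this assay: a number 23 percentage points lower from compound 2 to compound 4 (beyond the scatter), a modest change, which shows that the arm at this position bears on the maximal response, while compound 4 still gives 87% with a saturated chain carbon on that nitrogen. The two arms have the same counts of heavy atoms, hydrogen-bond donors and hydrogen-bond acceptors and each holds one six-membered aromatic ring, so those counts do not separate them, whereas the double bonds outside aromatic rings leave with the (3-carboxyphenyl)carbonyl. No measurement at hand bears on the origin of this step.

The single step exchanges the carbonyl link, the carboxyl group and the 2-hydroxyethoxy tail together, so the compounds shown leave open which of these parts accounts for the change. A benzyl arm carrying a carboxylic acid, or a 4-(2-aminoethoxy)benzyl arm with an amine at the end of the chain, would help to separate these contributions at this nitrogen.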